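Two measured analogues and an estimate for a third

This account rests on a few compounds, and the source may have more. Where it says the series, first, only, none or still open, it means among the compounds named here.

Compound 1 `COc1cccc(CNCCCNc2ccnc3cc(Oc4ccccc4)ccc23)c1O`: 6800 nM
Compound 2 `COc1ccc(Oc2ccc3c(NCCCNCc4cccc(OC)c4O)ccnc3c2)cc1`: 5500 nM

Among the measured compounds shown here, the two compounds measured so far were tested in an ADME assay on HepG2 cells (Homo sapiens) for cytotoxicity, read by luminescence, CellTiter-Glo and ATP content, with a stated time of 72 h; on this read-out lower numbers stand for an effect already at smaller amounts and higher numbers for an effect only at larger amounts of compound. For the measured compounds named here, compound 1 gives 6800 nM and compound 2 gives 5500 nM; the only step between them, a 1.2-fold lower number from compound 1 to compound 2 (0.09 log units; within the scatter), lies within the scatter, so the two numbers cannot be told apart. Compound 2 holds the lowest of the two numbers, with compound 1 as its nearest neighbour at a gap that is also within the scatter.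

Compound 3 `COc1cccc(CNCCCNc2ccnc3cc(Cc4ccccc4)ccc23)c1O` is not yet measured. It differs from compound 2 in one place: benzyl in place of 4-methoxyphenoxy on an aromatic carbon. Going by the values given here, no measured step in this set touches that part of the shared core; the one step available, from compound 1 to compound 2, concerns a different position and was within the scatter. With nothing in the data pointing either way, the account expects for compound 3 no shift beyond the scatter in this assay, that is, a step of about a 1.1-fold higher number from compound 2 to compound 3 (0.04 log units; within the scatter). Compound 3 is therefore estimated at 6000 nM, with a range from 2500 nM to 15000 nM.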

Compound 3, half-maximal effective concentration: 5720 nM
Compound 3: the middle estimate sits 1.0-fold (0.02 log units) above what was measured; the measured number falls inside the stated range.
By their numbers in this assay, from the lowest: compounds 2, 3 and 1 (each within the scatter of the next).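

In this assay, among the compounds shown here, compound 3 is the first compound in which the whole group on this aromatic carbon of the shared core is exchanged, and not only a methoxy on it: benzyl in place of 4-methoxyphenoxy gives a 1.0-fold higher number from compound 2 to compound 3 (0.02 log units; within the scatter), and benzyl in place of phenoxy gives a 1.2-fold lower number from compound 1 to compound 3 (0.08 log units; within the scatter). Benzyl has no oxygen and no hydrogen-bond acceptors, whereas 4-methoxyphenoxy has hydrogen-bond acceptors, so among these three compounds this exchange leaves the number within the scatter, as did the methoxy step that was the only one available before. No supporting data bear on this result, and the three numbers alone offer no explanation for it.

On these data alone, all three groups at this position carry one six-membered aromatic ring of carbon only, so it remains open how the number would respond to an amine such as morpholine, a carboxylic acid or a single chlorine there. Also open, as far as these compounds go, is what a longer chain would do in place of the linking chain that all three compounds share, or a change to the methoxy and hydroxy groups on their other aromatic ring.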